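The source may hold more compounds than are shown below. What is called first, only, known or untested is meant among the compounds shown, and "the series" means these compounds.

Measured compounds in an ADME assay on the whole organism (Macaca fascicularis) for pharmacokinetics, read by LC-MS, using cassette dosing, at a dose of 1 mg/kg by the oral route; a higher number here means more compound in the circulation at the dose given, a lower number less compound in the circulation:
Compound 1, `CCCCN(c1nc2c(CO)cccc2o1)[C@H](C)c1ccc(-c2ccccc2-c2nnn[nH]2)cc1`, gives 20.7 nM.
Compound 2, `CCCCN(c1nc2c(C(=O)NS(C)(=O)=O)cccc2o1)[C@H](C)c1ccc(-c2ccccc2-c2nnn[nH]2)cc1`, gives 40.4 nM.
Compound 3, `CCCCN(c1nc2c(NC(C)=O)cccc2o1)[C@H](C)c1ccc(-c2ccccc2-c2nnn[nH]2)cc1`, gives 26.6 nM.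

Compound 3 stands second of the three numbers in this assay. Its nearest neighbour is compound 1, with a step of a 1.3-fold higher number from compound 1 to compound 3 (0.11 log units; within the scatter); the furthest is compound 2, with a step of a 1.5-fold lower number from compound 2 to compound 3 (0.18 log units; within the scatter). The third step, a 2.0-fold higher number from compound 1 to compound 2 (0.29 log units; within the scatter), is also within the scatter, so the three measured compounds cannot be told apart on these numbers.

Compound 4, `CCCCN(c1nc2c(-c3ccccn3)cccc2o1)[C@H](C)c1ccc(-c2ccccc2-c2nnn[nH]2)cc1`, has not been measured in this assay. The change from compound 3 is pyridin-2-yl in place of acetamido on an aromatic carbon. Among the measured compounds shown here, no measured step exchanges an amide or an alcohol for an aromatic ring at this position; the steps that bear on it are the three substitutions at the same aromatic carbon, all within the scatter. On that basis no step beyond the scatter is expected from compound 3 to compound 4, and the expected step is a 1.1-fold lower number from compound 3 to compound 4 (0.03 log units; within the scatter). The estimate for compound 4 in this assay is 25 nM, with a range from 8 nM to 75 nM.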

Compound 4, maximal plasma concentration: 124 nM
Estimate against measurement, compound 4: 5.0-fold (0.70 log units) below; measured number above the stated range.
By their numbers in this assay, from the lowest: compounds 1, 3 and 2 (each within the scatter of the next); then compound 4.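

In this assay this aromatic carbon had shown no difference among hydroxymethyl, acetamido and (methylsulfonyl)carbamoyl, but it does respond to the group placed on it: pyridin-2-yl gives a 4.7-fold higher number from compound 3 to compound 4 (0.67 log units; beyond the scatter) and a 3.1-fold higher number from compound 2 to compound 4 (0.49 log units; beyond the scatter) and a 6.0-fold higher number from compound 1 to compound 4 (0.78 log units; beyond the scatter) with all three steps beyond the scatter. The group is the only one of the four with a ring, and against acetamido the change both adds a six-membered aromatic ring and removes the hydrogen-bond donor, so the step from compound 3 cannot say which of these two differences counts. Nothing at hand explains why the number rises with this group.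

Going by these compounds, whether the ring itself or its nitrogen goes with the higher number stays open, and phenyl, which has no ring nitrogen, or a saturated ring such as piperidine at this carbon would begin to separate the two. Also open, on these data alone, is whether an amine or a carboxylic acid on this aromatic carbon would fall with the three earlier compounds or with compound 4.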